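The compounds below may be only part of what the source reports. "The series", "measured", "known", "first", "only" and "open" are said of these compounds alone.

compound 1 `CCNC(=O)Nc1sc2ccccc2c1C(=O)N1CCN(C2CCN(C(=O)CC(C)C)CC2)CC1`: "not determined" (no result reported)
compound 2 `CCNC(=O)Nc1sc2ccccc2c1C(=O)N1CCN(C2CCN(C(=O)OC3CCCC3)CC2)CC1`: 512 nM

In a functional assay on HepG2 cells (Homo sapiens) for inhibition, read by scintillation counting, with a stated time of 2 h (on this read-out lower numbers stand for stronger inhibition and higher numbers for weaker inhibition), compound 2 gives 512 nM. Among the measured compounds shown here, this is the only number, so compound 2 cannot yet be ranked against another compound. Compound 3 `CCNC(=O)Nc1sc2ccccc2c1C(=O)N1CCN(C2CCN(C(=O)NC(C)(C)C)CC2)CC1` carries (tert-butyl)amino in place of cyclopentyloxy on a carbonyl carbon. For the measured compounds named here, no measured step is available as a guide. In this assay, the expected 1.2-fold higher number from compound 2 to compound 3 (0.07 log units; within the scatter) stays within the usual scatter, with no direction favoured. For compound 3 the estimated value is 600 nM, with an expected range of 150 nM to 2400 nM.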

Compound 3, half-maximal inhibitory concentration: 775 nM
Estimate against measurement, compound 3: 1.3-fold (0.11 log units) below; low and high end bracket the measured number.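

In this assay, among the compounds shown here, the step of a 1.5-fold higher number from compound 2 to compound 3 (0.18 log units; within the scatter) gives the first reading at this position. On the carbonyl carbon, the open-chain (tert-butyl)amino, with its hydrogen-bond donor, and the ring-bearing cyclopentyloxy, without one, read alike in this pair. No evidence on the reason is at hand. Open, from the compounds shown here alone, is how a phenyl ring or a small primary amine on the same carbonyl carbon would read. Also open, going by these compounds, is whether any group at this position moves the number beyond the scatter.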